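Lengthening the hydroxamate linker of compound 1

The source may hold more compounds than are shown below. What is called first, only, known or untested is meant among the compounds shown, and "the series" means these compounds.

Compound 1, `Cn1cc(-c2ccccc2Oc2ccccc2)c2cc(C(=O)NCCCC(=O)NO)[nH]c2c1=O`: 144 nM
Compound 2, `Cn1cc(-c2ccccc2Oc2ccccc2)c2cc(C(=O)NCc3ccc(C(=O)Nc4ccccc4N)cc3)[nH]c2c1=O`: > 500 nM
Compound 3, `CC(C)Oc1ccc(C(C)(C)O)cc1-c1cn(C)c(=O)c2[nH]c(C(=O)NCCCCCCC(=O)NO)cc12`: 5.4 nM

Of the compounds shown here, three have been measured in an assay on isolated protein for inhibition of protein deacetylase HDAC6 (Homo sapiens), read by fluorescence; on this read-out lower numbers stand for stronger inhibition and higher numbers for weaker inhibition. Compound 1 gives 144 nM. Compound 3, whose chain to the hydroxamate is longer and whose aryl substituents differ, gives 5.4 nM. For compound 2 only a limit of the assay is recorded, > 500 nM. Among the numbers shown, compound 1 therefore stands highest, with compound 3 the nearest and lying beyond the scatter below it. The one limit is summarised as the limit of > 500 nM in this assay, at which 1 of the 3 values shown sits.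

Compound 4, `Cn1cc(-c2ccccc2Oc2ccccc2)c2cc(C(=O)NCCCCC(=O)NO)[nH]c2c1=O`, has not yet been measured. It differs from compound 1 by (hydroxycarbamoyl)methyl in place of hydroxycarbamoyl on a saturated chain carbon, three bonds along the chain from an amide-type nitrogen. For the measured compounds named here, no measured pair shows this change on its own, since compound 3 also carries different aryl substituents, so the comparison of compound 1 with compound 3 gives only a hint of the direction.

Compound 4 is expected to sit below compound 1, with the step of a 2.9-fold lower number from compound 1 to compound 4 (0.46 log units; beyond the scatter) estimated to lie beyond the scatter. The estimate for compound 4 is 50 nM, with a range from 15 nM to 200 nM.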

Compound 4, half-maximal inhibitory concentration: 4 nM
Compound 4: the middle estimate sits 13-fold (1.10 log units) above what was measured, outside the stated range (below it).
By their numbers in this assay, from the lowest: compounds 4 and 3 (each within the scatter of the next); then compound 1. At a limit, above all of these: compound 2.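

Replacing hydroxycarbamoyl with (hydroxycarbamoyl)methyl on a saturated chain carbon, three bonds along the chain from an amide-type nitrogen, gives a 36-fold lower number from compound 1 to compound 4 (1.56 log units; beyond the scatter) in this assay, a large step. For the compounds shown here, compound 3 had hinted at a direction, but its aryl substituents differ as well, so no earlier pair could separate the chain from the rest of the molecule. Here the rest of compound 1 stays unchanged, which shows that this one change at this position is enough on its own to produce a step of this size. The compounds shown offer no measurement that explains why the step is so large.

As far as these compounds go, it remains open how the read-out in this assay continues along the series, with 2-(hydroxycarbamoyl)ethyl, 3-(hydroxycarbamoyl)propyl or 4-(hydroxycarbamoyl)butyl at this position on the core of compound 1, and whether the gain keeps growing, levels off or reverses. Also open, from the compounds shown here alone, is whether a carboxylic acid or a primary amide at the end of the same chain, in place of the hydroxycarbamoyl group, would retain any of this gain.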